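The source may hold more compounds than are shown below. What is called first, only, known or untested is meant among the compounds shown, and "the series" means these compounds.

In a functional assay on PC-3 cells (Homo sapiens) for cytotoxicity, read by sulforhodamine B assay, with a stated time of 72 h (on this read-out lower numbers stand for stronger inhibition of growth and higher numbers for weaker inhibition of growth), three compounds have been measured so far:

Compound 1 `O=C(Nc1ccccc1O)C1CCc2ccccc2N1` gives 4310 nM
Compound 2 `O=C(Nc1cc(C(F)(F)F)cc(C(F)(F)F)c1)C1CCc2ccccc2N1` gives 8120 nM
Compound 3 `O=C(Nc1cc(C(F)(F)F)cc(C(F)(F)F)c1)C1CCc2ccccc2N1C(=O)c1cccc(Cl)c1` gives 1050 nM

Compound 1 and compound 2 share the same bicyclic core and the same amide link, but the aryl group on the amide nitrogen differs between them in more than one place; the difference between the two cores is not broken down here. Their two values lie within the usual scatter of each other, so nothing is said about which of the two is stronger in this assay.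

Compound 3 arises from compound 2 by a single change, ((3-chlorophenyl)carbonyl in place of hydrogen on a nitrogen on an aromatic ring in a ring). In this assay this gave a 7.7-fold lower number from compound 2 to compound 3 (0.89 log units; beyond the scatter), a step that lies beyond the scatter.

Compound 4 `O=C(Nc1ccccc1O)C1CCc2ccccc2N1C(=O)c1cccc(Cl)c1` carries the same change on the core of compound 1: (3-chlorophenyl)carbonyl in place of hydrogen on a nitrogen on an aromatic ring in a ring. The place of the change is described in the same words for both pairs, so this is the same change made on a second aryl amide. Among the compounds with values here, the expectation for compound 4 rests on the step seen from compound 2 to compound 3, a 7.7-fold lower number from compound 2 to compound 3 (0.89 log units; beyond the scatter), with the single precedent allowing only a moderate confidence that the step carries over to the other aryl amide. Compound 4 is therefore expected to show a step of about a 6.2-fold lower number from compound 1 to compound 4 (0.79 log units; beyond the scatter) in this assay. Compound 4 is estimated at 700 nM, with a likely range from 250 nM to 2500 nM.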

Compound 4, concentration for 50% growth inhibition: 23300 nM
For compound 4 the middle estimate is 33-fold (1.52 log units) below the measured one; measured number outside the range, above it.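

The change did not carry over between the two aryl amides. In this assay, placing (3-chlorophenyl)carbonyl on the ring nitrogen of compound 1 gave a 5.4-fold higher number from compound 1 to compound 4 (0.73 log units; beyond the scatter), the opposite direction to the step seen on the other aryl amide, and the two steps clearly differ: the same change on two cores in this assay, a 7.7-fold lower number (0.89 log units; beyond the scatter) from compound 2 to compound 3 and a 5.4-fold higher number (0.73 log units; beyond the scatter) from compound 1 to compound 4, 42-fold (1.62 log units) apart, beyond the scatter of two such steps. This shows that, among the compounds shown, the effect of this change depends on the rest of the molecule, so a step measured on one aryl amide cannot be transferred to another, but with only two pairs it does not show which part of the aryl amide is responsible, nor does it give any reason for the reversal.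

As far as these compounds go, the aryl groups of the two pairs differ in more than one place, so it remains open whether the hydroxyl group, the two trifluoromethyl groups or some combination decides the direction of the step. Also open, from the compounds shown here alone, are how a plain phenyl amide or a methoxy-bearing aryl amide would respond to the same change, and whether an acetyl group on the ring nitrogen would split the same way as (3-chlorophenyl)carbonyl.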